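Acetyl for Acetamido on the Shared Core of Compound 1

The source may hold more compounds than are shown below. What is called first, only, known or untested is meant among the compounds shown, and "the series" means these compounds.

Measured so far in a functional assay for inhibition, with Homo sapiens as the target; a higher number here means a weaker inhibitor, a lower number a stronger inhibitor:
compound 1 `CC(=O)Nc1ccc(Nc2nccc(-c3cccnc3)n2)cc1` gives 3600 nM
compound 2 `CC(=O)Nc1ccc(Nc2nccc(-c3ccncc3)n2)cc1` gives 5300 nM

Of the two numbers in this assay, compound 1 has the lowest, and its nearest neighbour is compound 2. For the measured compounds named here, the only measured step between these two is a 1.5-fold higher number from compound 1 to compound 2 (0.17 log units; within the scatter), a swap of pyridin-4-yl in place of pyridin-3-yl on an aromatic carbon; it lies within the scatter and leaves the rest of the shared core untouched.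

Compound 3 `CC(=O)c1ccc(Nc2nccc(-c3cccnc3)n2)cc1` has not been measured. It differs from compound 1 in one place:
acetyl in place of acetamido on an aromatic carbon
The acetamido group that leaves carries a hydrogen-bond donor; the acetyl that enters carries none. Going by the values given here, no measured step touches this group, so nothing among the measured compounds tells how this assay responds to it, and the step from compound 2 to compound 1 is of a different kind. The expectation therefore rests on compound 1 alone, with a wide band around it. For compound 3 the estimate in this assay is 5000 nM, with a range from 1500 nM to 16000 nM. That estimate means a step of a 1.4-fold higher number from compound 1 to compound 3 (0.14 log units; within the scatter), expected to be small or none beyond the scatter.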

Compound 3, half-maximal inhibitory concentration: 800 nM
Compound 3: the middle estimate sits 6.3-fold (0.80 log units) above what was measured; the measured number lies below the stated range.
By their numbers in this assay, from the lowest: compound 3; then compounds 1 and 2 (each within the scatter of the next).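

For the compounds shown here, this position on the shared core turns out to respond in this assay: the change gives a 4.5-fold lower number from compound 1 to compound 3 (0.65 log units; beyond the scatter), whereas the only earlier step, at the pyridine on the other side of the core, stayed within the scatter. The acetamido group, with its hydrogen-bond donor, is therefore not needed for activity on the aromatic carbon para to a large group, since the acetyl that replaces it has 0 hydrogen-bond donors and still gives the lower number, though this rests on this single pair of compounds. On these data alone, nothing given here explains the shift, and whether it follows from the loss of the amide hydrogen, the loss of the nitrogen or the shorter group remains unknown.

The compounds shown leave open how other groups at this carbon would compare, such as an amine, a carboxylic acid, a nitrile or a longer chain like propanoyl, and so whether the carbonyl that acetamido and acetyl share matters at all. They also leave open whether acetyl gives a similar step when the core carries pyridin-4-yl in place of pyridin-3-yl.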